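The compounds below may be only part of what the source reports. "The series", "measured", "known", "first", "only" and "open" are said of these compounds alone.

Working notes on the series, all on the shared core. In a functional assay on KBVIN cells (Homo sapiens) for antiproliferative activity, read by sulforhodamine B assay, with a stated time of 3 days (on this read-out higher numbers stand for an effect only at larger amounts of compound and lower numbers for an effect already at smaller amounts), compound 1 `CCC1=C(O)c2c(oc(-c3ccc(C(C)C)cc3)cc2=O)C(CC)(CC)C1=O`, with isopropyl on the aromatic ring, gives 1.08 uM. For the measured compounds named here, compound 2 `CCC1=C(O)c2c(oc(-c3ccc(OC(F)(F)F)cc3)cc2=O)C(CC)(CC)C1=O`, with trifluoromethoxy instead, gives 9.95 uM, the higher of the two numbers so far. Going by the values given here, the one measured step is a 9.2-fold higher number from compound 1 to compound 2 (0.96 log units; beyond the scatter), and it lies beyond the scatter.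

Next is compound 3 `CCC1=C(O)c2c(oc(-c3ccc(F)cc3)cc2=O)C(CC)(CC)C1=O`, with fluoro in place of trifluoromethoxy on an aromatic carbon. The change sits para to a large group.

Among the compounds with values here, only that single step bears on this change, and only indirectly: trifluoromethoxy is the group that entered there and leaves here, while fluoro has no measured precedent. Two compounds establish no trend. Compound 2 at 9.95 uM is the higher reference and compound 1 at 1.08 uM the lower, so a landing between them is the working expectation, with the direction downward from compound 2 in this assay.

The expected move is a 2.2-fold lower number from compound 2 to compound 3 (0.34 log units; beyond the scatter), smaller than the measured step. For compound 3 the estimated value is 4.5 uM, with an expected range from 1.3 uM to 14 uM.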

Compound 3, concentration for half-maximal effect: 1.85 uM
Estimate against measurement, compound 3: 2.4-fold (0.39 log units) above; the measured number falls inside the stated range.
By their numbers in this assay, from the lowest: compounds 1 and 3 (each within the scatter of the next); then compound 2.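

In this assay, the removal of trifluoromethoxy in favour of fluoro at this place on the aromatic ring gives a clear step (a 5.4-fold lower number from compound 2 to compound 3 (0.73 log units; beyond the scatter)), so the number of compound 2 is tied to the group it carries and not to the shared core alone. Fluoro and isopropyl, by contrast, cannot be told apart here (a 1.7-fold higher number from compound 1 to compound 3 (0.23 log units; within the scatter)), which shows that two quite different groups at this carbon can give numbers within the scatter of each other, leaving trifluoromethoxy as the only one of the three that stands apart. Among these three compounds, then, the first measured step reflects something particular to trifluoromethoxy rather than a general loss on leaving isopropyl, though nothing at hand accounts for that difference.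

Still open, going by these compounds, is whether the standing of compound 2 goes with the oxygen link or with the trifluoromethyl part, which a methoxy or a trifluoromethyl group at the same carbon would separate. Also open, on these data alone, is how far this place tolerates other kinds of group, such as an amine, a carboxylic acid or a longer chain, and whether the tie between fluoro and isopropyl would hold for them.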